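Exchange at the chain carbon: phenylsulfanyl to allyl

This account rests on a few compounds, and the source may have more. Where it says the series, first, only, none or still open, it means among the compounds named here.

Two members of the series have so far been run in an assay (Equus caballus) for inhibition of Thromboxane-A synthase (Homo sapiens), using microsomes; a higher number here means a weaker inhibitor, a lower number a stronger inhibitor. Compound 1 `CC(C)(CCCC/C=C(\c1ccccc1)c1cccnc1)C(=O)O` gives 45 nM. Compound 2 `O=C(O)C(CCC/C=C(\c1ccccc1)c1cccnc1)Sc1ccccc1` gives 33 nM in this assay. The gap between these two numbers lies within the scatter, so compound 2 and compound 1 stand together and neither can be set apart from the other on present evidence.

The next member, compound 3 `C=CCC(CCC/C=C(\c1ccccc1)c1cccnc1)C(=O)O`, has not been measured. It differs from compound 2 in one place: allyl in place of phenylsulfanyl on a saturated chain carbon bound to a carbonyl carbon and a saturated chain carbon. For the measured compounds named here, no measured pair reports a step for this exchange, and the only comparison in hand, that of compound 2 with compound 1, shows no difference beyond the scatter. From compound 2 a step of a 1.4-fold higher number from compound 2 to compound 3 (0.13 log units; within the scatter) is expected, small and toward a higher number if anything, most likely within the scatter. Compound 3 is accordingly estimated at 45 nM, with a range from 15 nM to 150 nM.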

Compound 3, half-maximal inhibitory concentration: 50 nM
Compound 3: the middle estimate sits 1.1-fold (0.05 log units) below what was measured, and the stated range covers the measured number.
By their numbers in this assay, from the lowest: compounds 2, 1 and 3 (each within the scatter of the next).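

Working notes on the chain carbon: in this assay, allyl in place of phenylsulfanyl gives a 1.5-fold higher number from compound 2 to compound 3 (0.18 log units; within the scatter), so an open group with a double bond takes the place of a group carrying a six-membered aromatic ring and sulfur without a change beyond the scatter. The comparison with the gem-dimethyl acid gives a 1.1-fold higher number from compound 1 to compound 3 (0.05 log units; within the scatter), and this too stays within the scatter, so the three compounds cannot be separated and this position has so far tolerated each group placed on it. No measurement bears on why these exchanges leave the number where it is.

All groups compared here at this carbon carry no net charge. An amine or a hydroxyl group on this carbon, or a longer chain in place of allyl, would show whether this tolerance extends further.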